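Series notes: carbamoyl in place of methylamino at compound 3

The source may hold more compounds than are shown below. What is called first, only, known or untested is meant among the compounds shown, and "the series" means these compounds.

Three compounds share one core, differing in the group on the aromatic carbon opposite the ring oxygen and in the halogen on the pendant ring. In an assay on isolated protein (strain Sprague-Dawley) for inhibition of Amine oxidase [flavin-containing] B (Rattus norvegicus), read by spectrophotometry, with a stated time of 5 min (on this read-out higher numbers stand for weaker inhibition and lower numbers for stronger inhibition), compound 1 `COc1cc(=O)oc2cc(OCc3cccc(F)c3)ccc12` gives 36.3 nM, compound 2 `CCOc1cc(=O)oc2cc(OCc3cccc(Br)c3)ccc12` gives 126 nM, and compound 3 `CNc1cc(=O)oc2cc(OCc3cccc(Cl)c3)ccc12` gives 8.71 nM. Going by the values given here, compound 3 stands lowest of the three, and both gaps to it lie beyond the scatter, so it is the most potent measured member; no single-point step links these three, so nothing more is read from their pairwise differences.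

Compound 4 `NC(=O)c1cc(=O)oc2cc(OCc3cccc(Cl)c3)ccc12` is not yet measured. Relative to compound 3 the change is carbamoyl in place of methylamino on an aromatic carbon. Among the compounds with values here, no measured pair shows this swap, so the direction is uncertain; the working expectation is a modest weakening, a step from compound 3 to compound 4 of about a 2.9-fold higher number from compound 3 to compound 4 (0.46 log units; beyond the scatter), though a step within the scatter would not surprise. Compound 4 is therefore estimated at 25 nM in this assay, with a range of 6 nM to 100 nM.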

Compound 4, half-maximal inhibitory concentration: 234 nM
The estimate for compound 4 lay 9.4-fold (0.97 log units) below the measured number; the measured number lies above the stated range.
By their numbers in this assay, from the lowest: compound 3; then compound 1; then compounds 2 and 4 (each within the scatter of the next).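

In this assay, going by these compounds alone, this position proves sensitive to the group it carries: with the rest of the molecule unchanged, carbamoyl in place of methylamino gives a 27-fold higher number from compound 3 to compound 4 (1.43 log units; beyond the scatter), the first step that isolates a single place. The hydrogen-bond donor and acceptor counts are the same for both groups and neither carries a net charge, so these counts do not track the step; carbamoyl differs in adding an oxygen and a double bond outside aromatic rings. Nothing measured here bears on the cause of this step.

On these data alone, whether the low number of compound 3 needs methylamino specifically remains open, and an unsubstituted amine, dimethylamino or a carboxylic acid at this place would test that. Also open, as far as these compounds go, is whether the step holds with fluorine or bromine on the pendant ring, since compound 1 and compound 2 differ from compound 3 in more than one place.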